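A few compounds are considered here, and "the series" means these few. Any claim that something is new, unique, unknown or untested is made for them only; others in the source may bear on it.

In an ADME assay on BEAS-2B cells (Homo sapiens) for cytotoxicity, read by MTT assay, with a stated time of 72 h (a lower number here means a stronger inhibitor of growth, a higher number a weaker inhibitor of growth), compound 3 `N#C[Se]c1ccc(NC(=O)Oc2ccc(F)cc2)cc1` gives 45600 nM. Among the three compounds measured so far, this is the second highest number. The nearest neighbour is compound 1 `COc1ccc(OC(=O)Nc2ccc([Se]C#N)cc2)cc1`, which gives 48400 nM; the two lie within the scatter of each other. Compound 2 `CCCCOC(=O)Nc1ccc([Se]C#N)cc1` gives 12200 nM, a number that sits well beyond the scatter from compound 3. Compound 4 `Cc1ccc(OC(=O)Nc2ccc([Se]C#N)cc2)cc1` has not yet been measured. It differs from compound 3 by methyl in place of fluoro on an aromatic carbon. Among the measured compounds shown here, one measured step bears on this change: a 1.1-fold lower number from compound 1 to compound 3 (0.03 log units; within the scatter), in which one small group on an aromatic carbon was exchanged for another without moving the number beyond the scatter. Since the present change is again the exchange of one small group for another on an aromatic carbon, no step beyond the scatter is expected in this assay. Compound 4 is therefore estimated at 45000 nM, with a likely range from 20000 nM to 95000 nM. This expectation amounts to a step of a 1.0-fold lower number from compound 3 to compound 4 (0.01 log units; within the scatter).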

Compound 4, concentration for total growth inhibition: 15300 nM
For compound 4 the middle estimate is 2.9-fold (0.47 log units) above the measured one; measured number outside the range, below it.
By their numbers in this assay, from the lowest: compounds 2 and 4 (each within the scatter of the next); then compounds 3 and 1 (each within the scatter of the next).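

In this assay this position, on an aromatic carbon para to a large group, responds to the exchange of one small group for another: a 3.0-fold lower number from compound 3 to compound 4 (0.47 log units; beyond the scatter), and a 3.2-fold lower number from compound 1 to compound 4 (0.50 log units; beyond the scatter). The earlier exchange of methoxy for fluoro stayed within the scatter, so the position seemed indifferent, but methyl now separates from both of those groups, giving a stronger inhibitor of growth. No measurement at hand explains why methyl behaves differently from fluoro and methoxy.

With only these three groups shown at this position, it remains open whether methyl is unusual or whether a longer chain such as ethyl would give a similar number. Going by these compounds, the effect of chloro or an amine at the same position also remains open.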